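Replacing a butyl with a thiophene sulfonyl on the aryl amine

The source may hold more compounds than are shown below. What is called first, only, known or untested is meant among the compounds shown, and "the series" means these compounds.

Of the compounds shown here, three sharing one core have been tested in a functional assay on HEK293 cells (Homo sapiens) for cytotoxicity; a higher number here means that more compound is tolerated, a lower number that less compound is tolerated. Compound 3 `CCCCNc1cccc(N2C[C@@H](c3ccc(OC)c(OC4CCCC4)c3)CC2=O)c1` carries a butylamino group on its aromatic ring. In this assay compound 3 gives > 10000 nM, which is a limit of the assay and not a number. Compound 1 `COc1ccc([C@H]2CC(=O)N(c3ccc(C)c(N)c3)C2)cc1OC1CCCC1` gives > 10000 nM, again a limit. Compound 2 `COc1ccc([C@H]2CC(=O)N(c3ccccc3C)C2)cc1OC1CCCC1` gives > 10000 nM, also a limit. Within the data shown here, the one step between measured compounds that differ in a single place, a step that the two limits leave unreadable from compound 1 to compound 2, cannot be read, since both of its ends are limits. All that the numbers offer is the limit of > 10000 nM in this assay, at which 3 of the 3 values shown sit, so no measured change in this series has yet moved the read-out into the measurable range.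

Compound 4 `COc1ccc([C@H]2CC(=O)N(c3cccc(NS(=O)(=O)c4cc(Br)c(Cl)s4)c3)C2)cc1OC1CCCC1` differs from compound 3 in one place: (4-bromo-5-chlorothiophen-2-yl)sulfonyl in place of butyl on a nitrogen on an aromatic ring. Among the measured compounds shown here, no measured step bears on this kind of exchange, and the only guide is the shared limit of the three measured compounds. Compound 4 is therefore expected to tolerate about as much compound as its neighbours, with an estimated value of 15000 nM and a range from 5000 nM to 50000 nM. The expected step that the limit leaves unreadable from compound 3 to compound 4 is most likely one that stays hidden behind the same limit.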

Compound 4, half-maximal cytotoxic concentration: > 10000 nM
Compound 4 was reported as a limit; the forecaster's own chance of this, stated with the estimate: 80%; the middle value lies beyond the limit too.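

In this assay compound 4 gives > 10000 nM, which is a limit of the assay and not a number. Compound 3 also sits at a limit, so the exchange between compound 3 and compound 4 cannot be read as a step. The compounds shown leave open what concentration any of them would need to harm these cells, as all share one result: the limit of > 10000 nM in this assay, at which 4 of the 4 values shown sit.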